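This account rests on a few compounds, and the source may have more. Where it says the series, first, only, none or still open, it means among the compounds named here.

In a functional assay on G-361 cells (Homo sapiens) for antiproliferative activity, with a stated time of 72 h (a higher number here means a weaker inhibitor, a lower number a stronger inhibitor), the data so far give little to anchor on. Compound 1 `OC[C@H]1O[C@@H](n2cnc3c(NCc4ccccc4F)ncnc32)[C@H](O)[C@@H]1O` carries no result: compound 1 reads "not determined" (no result reported). Compound 2 `OC[C@H]1O[C@@H](n2cnc3c(NCc4ccccc4Br)ncnc32)[C@H](O)[C@@H]1O` reads > 166000 nM, which is a limit and not a number. With no other number available, the only reference point is the limit of > 166000 nM in this assay, at which 1 of the 2 values shown sits.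

Compound 3 `COc1ccccc1CNc1ncnc2c1ncn2[C@@H]1O[C@H](CO)[C@@H](O)[C@H]1O` departs from compound 2 in one place: methoxy in place of bromo on an aromatic carbon. This puts methoxy in place of bromo on an aromatic carbon, ortho to a large group, so that 2-bromobenzyl becomes 2-methoxybenzyl.

Among the compounds with values here, no measured step in this assay gives a size for this change. The expectation is a small move towards a lower number, most likely none beyond the scatter, and a second reading that is only a limit is quite possible. This expectation rests on compound 2 alone, whose limit is > 166000 nM. The estimated change is an at least 1.3-fold lower number from compound 2 to compound 3 (0.14 log units; that floor lies within the scatter). For compound 3 the expected value is 120000 nM, with an estimated range of 30000 nM to 166000 nM.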

Compound 3, half-maximal inhibitory concentration: > 166000 nM
Compound 3 was reported as a limit (the forecaster's own chance of this, stated with the estimate: 60%); middle value at least 1.3-fold (0.14 log units) away from the limit.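

In this assay compound 3 gives > 166000 nM, which is a limit and not a number. Compound 2 is likewise reported only as a limit, so no step can be read between compound 2 and compound 3. The compounds shown leave open whether 2-bromobenzyl and 2-methoxybenzyl differ at all in this assay, and by how much.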